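Halogenated arylidene analogues on a shared core: predicting compound 4

This account rests on a few compounds, and the source may have more. Where it says the series, first, only, none or still open, it means among the compounds named here.

Compound 1 `C=CCn1c(=O)/c(=C\c2cccc(Cl)c2)[nH]c(=O)/c1=C\c1ccccc1OC` gives 5200 nM in a functional assay on A549 cells (Homo sapiens) for cytotoxicity, read by CCK-8 assay, with a stated time of 72 h; on this read-out higher numbers stand for weaker inhibition and lower numbers for stronger inhibition.
Compound 2 `C=CCn1c(=O)/c(=C\c2cccc(F)c2)[nH]c(=O)/c1=C\c1ccccc1OC` gives 19700 nM in this assay.
Compound 3 `C=CCn1c(=O)/c(=C\c2ccccc2OC)[nH]c(=O)/c1=C\c1ccccc1OC` gives 22400 nM in this assay.

Compound 3 stands at the highest number of the three. Its nearest neighbour is compound 2, and the step of a 1.1-fold higher number from compound 2 to compound 3 (0.06 log units; within the scatter) lies within the scatter, so the two cannot be ordered. Compound 1 is furthest away, the step of a 4.3-fold higher number from compound 1 to compound 3 (0.63 log units; beyond the scatter) being beyond the scatter.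

Compound 4 `C=CCn1c(=O)/c(=C\c2ccc(F)c(Br)c2)[nH]c(=O)/c1=C\c1ccccc1OC` differs from compound 3 by 3-bromo-4-fluorophenyl in place of 2-methoxyphenyl on a double-bonded chain carbon bound to an aromatic carbon. Within the data shown here, two measured steps bear on this change. The step of a 4.3-fold higher number from compound 1 to compound 3 (0.63 log units; beyond the scatter) shows that moving from a halogenated phenyl to the 2-methoxyphenyl raised the number by a modest amount, while the step of a 1.1-fold higher number from compound 2 to compound 3 (0.06 log units; within the scatter) shows no change beyond the scatter for the fluoro analogue; the step of a 3.8-fold higher number from compound 1 to compound 2 (0.58 log units; beyond the scatter) shows that the choice of halogen matters. Compound 4 carries bromine and fluorine together, and a modest lowering of the number is therefore expected, as a 3.7-fold lower number from compound 3 to compound 4 (0.57 log units; beyond the scatter). Compound 4 is estimated at 6000 nM, within 2500 nM to 15000 nM.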

Compound 4, half-maximal inhibitory concentration: "not active" (no number reported)
Compound 4: no number reported, and the estimate cannot be compared.
By their numbers in this assay, from the lowest: compound 1; then compounds 2 and 3 (each within the scatter of the next).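

Among these compounds, compound 4 is reported as "not active" in this assay without a number, so no step linking it to compound 1, compound 2 or compound 3 can be read. The compounds shown leave open where compound 4 stands numerically against these three. No measured evidence shown bears on this result.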